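Shortening an ethoxy to methoxy on an inactive aniline

A few compounds are considered here, and "the series" means these few. Any claim that something is new, unique, unknown or untested is made for them only; others in the source may bear on it.

Compound 1 `CCOc1ccc(-c2nn3cc(-c4cccc(N)c4)nc3s2)cc1` is the free aniline of this set. In a functional assay on CCRF-CEM cells (Homo sapiens) for inhibition, read by cell counting, with a stated time of 3 days (a higher number here means a weaker inhibitor, a lower number a stronger inhibitor), compound 1 gives > 250000 nM, which is a limit of the assay and not a number, so compound 1 sits at the top of the values shown (the limit of > 250000 nM in this assay, at which 1 of the 3 values shown sits). Compound 3 `C=C(Br)C(=O)Nc1cccc(-c2cn3nc(-c4ccc(OCC)cc4)sc3n2)c1` gives 1400 nM, and compound 2 `C=C(Br)C(=O)Nc1cccc(-c2cn3nc(Cc4ccccc4)sc3n2)c1` gives 4200 nM. Compound 4 `COc1ccc(-c2nn3cc(-c4cccc(N)c4)nc3s2)cc1` differs from compound 1 by hydrogen in place of methyl on a saturated chain carbon bound to an oxygen on an aromatic ring. Neither measured step touches this place: the step of an at least 170-fold lower number from compound 1 to compound 3 (2.25 log units; beyond the scatter) adds the acrylamide to the aniline nitrogen, and the step of a 3.0-fold lower number from compound 2 to compound 3 (0.48 log units; beyond the scatter) swaps the group on the other end of the shared core. Both are changes of a different kind from the one-carbon shortening that leads to compound 4, which keeps the free aniline of compound 1. The expectation for compound 4 is therefore no step beyond the scatter, a number no higher from compound 1 to compound 4 (the limit leaves the size open), and most likely again only a limit. Compound 4 is estimated at 250000 nM, with a range from 60000 nM to 300000 nM.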

Compound 4, half-maximal inhibitory concentration: >= 250000 nM
Compound 4: no number, only a limit; the forecaster's own chance of this, stated with the estimate: 85%; the middle value sits exactly at the limit.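

In this assay compound 1 and compound 4 both give only limits, so the step from ethoxy to methoxy cannot be read. The compounds shown leave open whether that same shortening would change the number once the (1-bromoethenyl)carbonyl group sits on the aniline nitrogen, as in compound 3.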